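Bromination of a fused bicyclic core: two cores, one change

The compounds below may be only part of what the source reports. "The series", "measured", "known", "first", "only" and "open" are said of these compounds alone.

Compound 1 `Clc1ccc(Cc2nn3cc(-c4ccc(Cl)cc4Cl)nc3s2)cc1` and compound 3 `Clc1ccc(Cc2nn3c(Br)c(-c4ccc(Cl)cc4Cl)nc3s2)cc1` share one core; compound 2 `O=c1oc2ccccc2cc1-c1cn2nc(Cc3ccc(Cl)cc3)sc2n1` and compound 4 `O=c1oc2ccccc2cc1-c1nc2sc(Cc3ccc(Cl)cc3)nn2c1Br` share another. How the two cores differ is not broken down here.

In an ADME assay on CCRF-CEM cells (Homo sapiens) for cytotoxicity, with a stated time of 72 h (a lower number here means a stronger inhibitor, a higher number a weaker inhibitor), compound 1 gives > 250000 nM, which is a limit of the assay and not a number. Compound 3 gives 106000 nM in this assay. The change between them is bromo in place of hydrogen on an aromatic carbon, and it makes an at least 2.3-fold lower number from compound 1 to compound 3 (0.37 log units; beyond the scatter); the size of that step is bounded by the limit of > 250000 nM in this assay, at which 1 of the 3 values shown sits.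

Compound 2 gives > 10000 nM in this assay, again a limit rather than a number, as stated by the limit of > 10000 nM in this assay, at which 1 of the 3 values shown sits. Compound 4 is not yet measured in this assay. It differs from compound 2 by bromo in place of hydrogen on an aromatic carbon. This is the same kind of change as that from compound 1 to compound 3, not the same: in compound 4 the bromo sits next to the ring atom that bears a large group, whereas in compound 3 it sits next to the ring atom that bears a 2,4-dichlorophenyl group.

For compound 4 in this assay a step of an at least 1.4-fold lower number from compound 2 to compound 4 (0.15 log units; that floor lies within the scatter) is expected, resting on the step from compound 1 to compound 3 and on compound 2 sitting at a limit. The estimate for compound 4 in this assay is therefore 7000 nM, with a range from 1500 nM to 40000 nM.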

Compound 4, half-maximal inhibitory concentration: 3700 nM
The estimate for compound 4 lay 1.9-fold (0.28 log units) above the measured number, and the stated range covers the measured number.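

Working notes on the bromo change: in this assay, bromo in place of hydrogen on an aromatic carbon again goes with a lower number when carried from the core of compound 1 to the core of compound 2, here as an at least 2.7-fold lower number from compound 2 to compound 4 (0.43 log units; beyond the scatter). Compound 2 gives > 10000 nM, which is a limit of the assay and not a number. The direction of the change therefore holds on both cores shown, but this pair gives only a floor for the size of the step, and the two cores cannot be ranked by how much the change does: the same change on two cores in this assay, an at least 2.3-fold lower number (0.37 log units; beyond the scatter) from compound 1 to compound 3 and an at least 2.7-fold lower number (0.43 log units; beyond the scatter) from compound 2 to compound 4; the limit leaves it open whether they differ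

The compounds shown leave open whether another group on the same aromatic carbon, such as chloro, methyl, an amine or a carboxylic acid, would move the number in this assay in the same direction as bromo. They also leave open whether the step would hold on a core other than these two, or if the 4-chlorobenzyl group that both cores carry gave way to a longer chain.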